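A few compounds are considered here, and "the series" means these few. Any claim that something is new, unique, unknown or untested is made for them only; others in the source may bear on it.

Of the compounds shown here, two built on one shared core have been tested in a functional assay on MIA PaCa-2 cells (Homo sapiens) for cytotoxicity, read by MTT assay, with a stated time of 72 h; on this read-out lower numbers stand for stronger inhibition and higher numbers for weaker inhibition. Compound 1 `COc1cc(NC2=CC(=O)c3ncncc3C2=O)cc(OC)c1` gives 7700 nM in this assay. Compound 2 `COc1ccc(-c2ccc(NC3=CC(=O)c4ncncc4C3=O)cc2)cc1` gives 2100 nM, the lowest of the two numbers; its nearest neighbour is compound 1, whose number is higher by a margin beyond the scatter. Compound 3 `NS(=O)(=O)c1ccc(NC2=CC(=O)c3ncncc3C2=O)cc1` has not yet been tested. It differs from compound 2 in a single place: sulfamoyl in place of 4-methoxyphenyl on an aromatic carbon. Going by the values given here, no pair of measured compounds shows an exchange of this kind, so there is no measured step to lean on. With only the two numbers as a guide, the move from compound 2 to compound 3 is expected to bring a moderate rise in the number, that is, weaker inhibition, although an outcome inside the scatter cannot be ruled out. For compound 3 the estimate is 6000 nM, with a range from 2000 nM to 20000 nM, which means an expected step of a 2.9-fold higher number from compound 2 to compound 3 (0.46 log units; beyond the scatter).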

Compound 3, half-maximal inhibitory concentration: > 10000 nM
Compound 3: no number, only a limit (the forecaster's own chance of this, stated with the estimate: 10%); middle value at least 1.6-fold (0.22 log units) from the limit.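

In this assay, going by these compounds alone, putting sulfamoyl in place of 4-methoxyphenyl on an aromatic carbon, para to a large group, brings an at least 4.7-fold higher number from compound 2 to compound 3 (0.67 log units; beyond the scatter), the first exchange at this position that can be read, and it goes towards weaker inhibition by a margin beyond the scatter. Compound 3 stands at > 10000 nM, which is a limit of the assay and not a number: the limit of > 10000 nM in this assay, at which 1 of the 3 values shown sits. This position therefore does not take every group alike, and 4-methoxyphenyl cannot be swapped for sulfamoyl without a loss, though how large that loss is stays unfixed.

The compounds shown do not separate the part played by the aromatic ring that leaves from that of the sulfamoyl that enters. On these data alone, how a plain phenyl, an amine or a carboxylic acid on this carbon would stand in this assay remains open.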